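The compounds below may be only part of what the source reports. "The series", "measured", "known", "first", "only" and "open" are said of these compounds alone.

Measured compounds:
compound 1, `CC(C)(C)c1ccc(NC(=O)C2=CCN(c3ncccc3C(F)(F)F)CC2)cc1`: 6 nM
compound 2, `CC(C)(C)c1ccc(NC(=O)C2=CCN(c3ccccn3)CC2)cc1`: 27 nM

In an in vitro functional assay on 1321-N1 cells for antagonist activity at transient receptor potential cation channel subfamily V member 1 (Homo sapiens), read by FLIPR and calcium flux (on this read-out lower numbers stand for stronger inhibition and higher numbers for weaker inhibition), compound 2 gives the higher of the two numbers; compound 1 sits beside it with the lower value, and the gap between them is beyond the scatter. Going by the values given here, the only measured step is a 4.5-fold higher number from compound 1 to compound 2 (0.65 log units; beyond the scatter), which removes the trifluoromethyl from the shared core. Compound 3, `CC(C)(C)c1ccc(NC(=O)C2=CCN(c3ncccc3F)CC2)cc1`, is reached from compound 2 by the change (fluoro in place of hydrogen on an aromatic carbon), so a group of one heavy atom enters the same aromatic carbon that carried the trifluoromethyl in compound 1. Among the compounds with values here, the step in this assay that bears on it is therefore the one from compound 1 to compound 2, read backwards: filling that carbon again is expected to bring the number down, though the entering fluoro is a smaller group than the trifluoromethyl and the step is expected to fall short of that one. For compound 3 the value in this assay is estimated at 15 nM, with a range from 5 nM to 40 nM, which corresponds to a 1.8-fold lower number from compound 2 to compound 3 (0.26 log units; within the scatter).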

Compound 3, half-maximal inhibitory concentration: 19 nM
The estimate for compound 3 lay 1.3-fold (0.10 log units) below the measured number; the measured number falls inside the stated range.
By their numbers in this assay, from the lowest: compound 1; then compounds 3 and 2 (each within the scatter of the next).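

In this assay, fluoro on this aromatic carbon cannot be told apart from hydrogen: the step of a 1.4-fold lower number from compound 2 to compound 3 (0.15 log units; within the scatter) stays within the scatter, so compound 2 and compound 3 cannot be ordered. Trifluoromethyl on the same carbon remains distinct from fluoro, with a 3.2-fold higher number from compound 1 to compound 3 (0.50 log units; beyond the scatter) lying beyond the scatter, so of the three groups shown, only the trifluoromethyl of compound 1 stands apart. No evidence is available to explain how this position responds to these changes.

From the compounds shown here alone, whether chloro, methyl, or a nitrile on this carbon would read like trifluoromethyl or like hydrogen and fluoro remains open. Also open, going by these compounds, is how an amine or a carboxylic acid there would read in this assay, and whether these differences would hold on another part of the shared core.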